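The compounds below may be only part of what the source reports. "The series", "measured", "known", "first", "only" and "open" are said of these compounds alone.

Compound 1 `Cc1ccc(/C=C2\CCC/C(=C\c3ccccc3[N+](=O)[O-])C2=O)cc1` and compound 2 `Cc1ccc(/C=C2\CCC/C(=C\c3ccc([N+](=O)[O-])cc3)C2=O)cc1` are built from the same atoms joined differently; the difference between the two cores is not broken down here. Compound 3 `O=C1/C(=C/c2ccc(F)cc2)CCC/C1=C\c1ccccc1[N+](=O)[O-]` is compound 1 with one change, (fluoro in place of methyl on an aromatic carbon). In a functional assay on CCRF-CEM cells (Homo sapiens) for cytotoxicity, with a stated time of 72 h (on this read-out higher numbers stand for weaker inhibition and lower numbers for stronger inhibition), compound 1 gives 6090 nM, compound 2 gives 8530 nM and compound 3 gives 1510 nM. Compound 1 and compound 2 lie within the scatter of each other. The change on compound 1 gave a 4.0-fold lower number from compound 1 to compound 3 (0.61 log units; beyond the scatter). Compound 4 `O=C1/C(=C/c2ccc(F)cc2)CCC/C1=C\c1ccc([N+](=O)[O-])cc1`, not yet measured, carries the same change on compound 2: fluoro in place of methyl on an aromatic carbon. Because a 4.0-fold lower number from compound 1 to compound 3 (0.61 log units; beyond the scatter) was a clear step, a similar step is expected for compound 4, roughly a 3.7-fold lower number from compound 2 to compound 4 (0.57 log units; beyond the scatter), though one earlier example is thin ground. The estimate for compound 4 in this assay is 2300 nM, probably between 900 nM and 6000 nM.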

Compound 4, half-maximal inhibitory concentration: 18600 nM
Estimate against measurement, compound 4: 8.1-fold (0.91 log units) below; measured number above the stated range.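

On the core of compound 2, putting fluoro in place of methyl gave a 2.2-fold higher number from compound 2 to compound 4 (0.34 log units; beyond the scatter) in this assay, so the number moved the opposite way from the step on the core of compound 1. The two steps differ in direction and cannot be treated as one shared effect of the change: the same change on two cores in this assay, a 4.0-fold lower number (0.61 log units; beyond the scatter) from compound 1 to compound 3 and a 2.2-fold higher number (0.34 log units; beyond the scatter) from compound 2 to compound 4, 8.8-fold (0.94 log units) apart, beyond the scatter of two such steps. This shows that the result of this change did not carry from one core to the other here, but two pairs cannot explain the reversal or predict the result on a further core.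

Going by these compounds, it remains open whether a chloro or methoxy group in the same place would follow compound 3 or compound 4. Also open, on these data alone, is what an amine or a nitrile in place of the nitro group would do on either core.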